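The compounds below may be only part of what the source reports. "The series", "measured", "known", "first", "only" and "open" are said of these compounds alone.

Three compounds share one core and differ in a single group on an aromatic carbon. Compound 1 `O=C(N/N=C/c1cccc(F)c1)c1cccnc1Nc1cccc(C(F)(F)F)c1`, with fluoro there, gives 52.8% in a functional assay on the whole organism (strain Wistar) for inhibition, with Rattus norvegicus as the target, read by paw edema, with a stated time of 2 h, at a dose of 10 mg/kg by the intraperitoneal route; a lower number here means less inhibition, a higher number more inhibition at the dose given (going by the name of the read-out). Compound 2 `O=C(N/N=C/c1cccc(Cl)c1)c1cccnc1Nc1cccc(C(F)(F)F)c1`, with chloro, gives 63.5% in this assay, and compound 3 `O=C(N/N=C/c1cccc(O)c1)c1cccnc1Nc1cccc(C(F)(F)F)c1`, with hydroxy, gives 65.4% in this assay. Two steps go beyond the scatter: a number 10.7 percentage points higher from compound 1 to compound 2 (beyond the scatter) and a number 12.6 percentage points higher from compound 1 to compound 3 (beyond the scatter). The third does not: a number 1.9 percentage points higher from compound 2 to compound 3 (within the scatter). Compound 3 therefore holds the highest of the three numbers, clearly apart from compound 1 but not from compound 2.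

Compound 4 `O=C(N/N=C/c1ccc(O)c(O)c1)c1cccnc1Nc1cccc(C(F)(F)F)c1` follows from compound 3 by one change: hydroxy in place of hydrogen on an aromatic carbon. Going by the values given here, no measured step adds a hydroxy where hydrogen stood; the steps that bear on it only replace a halogen by hydroxy, and they were modest at most, with the hydroxy-for-chloro step within the scatter. A second hydroxy entering next to the first is therefore expected to move the number little, an estimated step of a number 2.6 percentage points higher from compound 3 to compound 4 (within the scatter). Compound 4 is expected to give 68% in this assay, within a range from 56% to 80%.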

Compound 4, a percentage reported as inhibition, in the whole organism at one dose (the size of the read-out at that dose, not a potency): 46.9%
Beside the measured number, compound 4's estimate is 21.1 percentage points above it; the whole stated range lies above it.
By their numbers in this assay, from the lowest: compounds 4 and 1 (each within the scatter of the next); then compounds 2 and 3 (each within the scatter of the next).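

Adding a hydroxy to turn 3-hydroxyphenyl into 3,4-dihydroxyphenyl is not a neutral change in this assay: it gives a number 18.5 percentage points lower from compound 3 to compound 4 (beyond the scatter) and is the first step in the series to a lower number from a compound carrying hydroxy. The effect of one hydroxy on this ring therefore does not carry over to a second: the catechol-type pattern gives a number 16.6 percentage points lower from compound 2 to compound 4 (beyond the scatter) and, against the fluoro compound, a number 5.9 percentage points lower from compound 1 to compound 4 (within the scatter) and so no longer stands apart from it. Nothing available here bears on the reason for this fall.

The compounds shown leave open whether the fall belongs to hydroxy as such or to any group entering at this place; a methoxy or an amine there would separate the two. Also open, on these data alone, is whether the same hydroxy would lower the number on the 3-chlorophenyl compound.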